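The source may hold more compounds than are shown below. What is called first, only, known or untested is meant among the compounds shown, and "the series" means these compounds.

Measured so far:
- compound 1, `CC1=C(C(=O)Nc2ccc(F)cc2)C(c2ccc([N+](=O)[O-])cc2)N=C(SCc2cccc(Cl)c2)N1`: 2.1%
- compound 2, `CC1=C(C(=O)Nc2ccc(F)cc2)C(c2ccc([N+](=O)[O-])cc2)N=C(SCc2ccc(Cl)cc2)N1`: 3.6%
- compound 3, `CC1=C(C(=O)Nc2ccc(Br)cc2)C(c2ccc(Cl)cc2Cl)N=C(SCc2ccccc2Cl)N1`: 3.1%

All three numbers come from a functional assay on the whole organism (artery, strain albino) with Rattus norvegicus as the target, with a stated time of 15 min, at a dose of 10 mg/kg by the oral route (a lower number here means less inhibition, a higher number more inhibition at the dose given (going by the name of the read-out)), and all lie close together. Compound 3 is the second highest of the three, yet its gaps to compound 2 and to compound 1 are both within the scatter, so no order among the three can be read from these numbers.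

The next compound is compound 4, `CC1=C(C(=O)Nc2ccc(Br)cc2)C(c2ccc(Cl)cc2Cl)N=C(SCc2ccc(F)cc2)N1`. It differs from compound 3 in one place: 4-fluorophenyl in place of 2-chlorophenyl on a saturated chain carbon bound to a sulfur.

Among the compounds with values here, the only measured step that touches the same place is a number 1.5 percentage points higher from compound 1 to compound 2 (within the scatter), which moved the chlorine on the phenyl of that benzyl group and left the read-out within the scatter. That step is not identical to the present one, which exchanges chlorine for fluorine as well as moving the substituent, and nothing measured here speaks to the halogen exchange itself. Within the data shown here, with the one relevant step flat and all three measured values lying in the same low region, no step beyond the scatter is expected in this assay.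

Compound 4 is therefore expected to give 3%, with a range from 0% to 9%. The estimated step is a number 0.1 percentage points lower from compound 3 to compound 4 (within the scatter), which is within the scatter.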

Compound 4, a percentage reported as inhibition, in the whole organism at one dose (the size of the read-out at that dose, not a potency): 3.6%
The estimate for compound 4 lay 0.6 percentage points below the measured number, within the range that was stated.
By their numbers in this assay, from the lowest: compounds 1, 3, 2 and 4 (each within the scatter of the next).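

In this assay, 4-fluorophenyl in place of 2-chlorophenyl on a saturated chain carbon bound to a sulfur gives a number 0.5 percentage points higher from compound 3 to compound 4 (within the scatter) and so leaves the read-out flat, even though the halogen and its place on the phenyl both change in one step. Within the data shown here, until now, the only step read at this position was a number 1.5 percentage points higher from compound 1 to compound 2 (within the scatter), a move of the chlorine alone with the rest of the molecule as in compound 1, so the flat result now also holds for a change of halogen with the rest of the molecule as in compound 3. Nothing at hand gives a reason for this flat result.

Because the halogen and its place change together in the new step, the compounds shown cannot separate the two, and they leave open whether any halogen on this phenyl matters at all. They also leave open whether something other than a halogenated phenyl at this position, such as a carboxylic acid, a dimethylamino group or a longer alkyl chain, would lift the read-out out of this low region.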